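Swapping iodo for trifluoromethyl on the triazole-linked phenyl

A few compounds are considered here, and "the series" means these few. Any claim that something is new, unique, unknown or untested is made for them only; others in the source may bear on it.

Measured compounds:
- compound 1 `O=C(Nc1cccc(OCc2cn(-c3ccccc3F)nn2)c1)Nc1ccc(Cl)c(C(F)(F)F)c1`: 1520 nM
- compound 2 `O=C(Nc1cccc(OCc2cn(-c3ccc(Br)cc3)nn2)c1)Nc1ccc(Cl)c(C(F)(F)F)c1`: 2730 nM
- compound 3 `O=C(Nc1cccc(OCc2cn(-c3cccc(I)c3)nn2)c1)Nc1ccc(Cl)c(C(F)(F)F)c1`: 4780 nM

All three share one core, a urea linking two aromatic rings, and differ only in the substituted phenyl on the triazole nitrogen. In a functional assay on HepG2 cells (Homo sapiens) for inhibition, read by MTT assay, with a stated time of 72 h (a higher number here means a weaker inhibitor, a lower number a stronger inhibitor), compound 3 gives 4780 nM, the highest number of the three. Its nearest neighbour is compound 2 (a 1.8-fold higher number from compound 2 to compound 3 (0.24 log units; within the scatter)), and the step of a 3.1-fold higher number from compound 1 to compound 3 (0.50 log units; beyond the scatter) is modest.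

Compound 4 `O=C(Nc1cccc(OCc2cn(-c3cccc(C(F)(F)F)c3)nn2)c1)Nc1ccc(Cl)c(C(F)(F)F)c1` keeps everything else and changes only the halogen on that phenyl: trifluoromethyl in place of iodo on an aromatic carbon. Going by the values given here, no measured pair shows this exact swap. Among the compounds with values here, the steps that bear on it are those varying the same phenyl, a 1.8-fold higher number from compound 1 to compound 2 (0.25 log units; within the scatter) and a 3.1-fold higher number from compound 1 to compound 3 (0.50 log units; beyond the scatter), which stayed within the scatter or moved only modestly. On that basis a small step in this assay, in either direction and probably inside the scatter, is expected for compound 4, and the estimate is 4000 nM, with a range from 1500 nM to 10000 nM, meaning an expected step of a 1.2-fold lower number from compound 3 to compound 4 (0.08 log units; within the scatter).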

Compound 4, half-maximal inhibitory concentration: 1270 nM
Compound 4: middle estimate off by 3.1-fold (0.50 log units), on the high side; the measured number lies below the stated range.
By their numbers in this assay, from the lowest: compounds 4, 1, 2 and 3 (each within the scatter of the next, the first and the last beyond it).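

Keeping the place on the phenyl fixed and changing only the group, from 3-iodophenyl to 3-(trifluoromethyl)phenyl, moves the number in this assay beyond the scatter (a 3.8-fold lower number from compound 3 to compound 4 (0.58 log units; beyond the scatter)), so the group at this place alone can shift the reading, something the earlier steps could not isolate, as each of them changed the group and its place together. The 4-bromophenyl compound also reads higher than the new compound (a 2.1-fold lower number from compound 2 to compound 4 (0.33 log units; beyond the scatter)), while the 2-fluorophenyl compound cannot be told apart from it (a 1.2-fold lower number from compound 1 to compound 4 (0.08 log units; within the scatter)), so these data show no simple rule that ties the number to one place on the ring. Nothing measured here accounts for the shift.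

The compounds shown carry only halogens or trifluoromethyl on this phenyl, which leaves open how a group of another kind, such as an amine, a carboxylic acid or a methoxy group, would read at the same place. Also open, as far as these compounds go, is how trifluoromethyl itself would read elsewhere on this ring, as it appears here at only one place.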